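Ring size on the sulfonyl chain: compound 3

This account rests on a few compounds, and the source may have more. Where it says the series, first, only, none or still open, it means among the compounds named here.

Compound 1 `CCCCCCCS(=O)(=O)/C=C/c1ccc(O)c(O)c1` and compound 2 `O=S(=O)(/C=C/c1ccc(O)c(O)c1)CC1CCCC1` share one core and differ only at the saturated chain carbon bound to the sulfonyl sulfur. In a functional assay, read by fluorescence and spectrophotometry, with a stated time of 1 h (a higher number here means that more compound is needed for the effect, a lower number that less compound is needed), compound 1 gives 7100 nM and compound 2 gives 9400 nM. Compound 2 carries the highest of the two numbers, with compound 1 nearest; the step of a 1.3-fold higher number from compound 1 to compound 2 (0.12 log units; within the scatter) lies within the scatter, so the two cannot be ordered.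

Compound 3 `O=S(=O)(/C=C/c1ccc(O)c(O)c1)CC1CCCCC1` has not yet been measured. It differs from compound 2 as follows: cyclohexyl in place of cyclopentyl on a saturated chain carbon bound to a sulfonyl sulfur. For the measured compounds named here, the only measured step that bears on this change is a 1.3-fold higher number from compound 1 to compound 2 (0.12 log units; within the scatter), which shows that exchanging one group for another at this place left this assay essentially unmoved. A further exchange of this kind is therefore expected to give no step beyond the scatter. The expected step is a 1.2-fold lower number from compound 2 to compound 3 (0.07 log units; within the scatter). Compound 3 is estimated at 8000 nM, with a range from 3000 nM to 20000 nM.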

Compound 3, half-maximal effective concentration: 7500 nM
Compound 3: middle estimate off by 1.1-fold (0.03 log units), on the high side, and the stated range covers the measured number.
By their numbers in this assay, from the lowest: compounds 1, 3 and 2 (each within the scatter of the next).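

Cyclohexyl in place of cyclopentyl on a saturated chain carbon bound to a sulfonyl sulfur gives a 1.3-fold lower number from compound 2 to compound 3 (0.10 log units; within the scatter) in this assay and adds ring size to the exchanges tested at this place. Cyclohexyl in place of hexyl gives a 1.1-fold higher number from compound 1 to compound 3 (0.02 log units; within the scatter) and so, like the cyclopentyl exchange, shows no separable difference between the open chain and a ring; hexyl, cyclopentyl and cyclohexyl cannot be ordered across compound 1, compound 2 and compound 3. No evidence is available on what lies behind this flat response.

Hexyl, cyclopentyl and cyclohexyl are all groups of carbon only, so it remains open whether an amine or a carboxylic acid at this place would give a step beyond the scatter. As far as these compounds go, a methyl group or a phenyl ring at this place is equally open.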